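The source may hold more compounds than are shown below. What is called first, only, known or untested is meant among the compounds shown, and "the series" means these compounds.

Measured so far in an assay on CHO cells for displacement of a labelled ligand from adenosine receptor A2b (Homo sapiens), read by scintillation counting, with a stated time of 75 min, in the presence of a further agent that is not named here; on this read-out higher numbers stand for weaker inhibition and lower numbers for stronger inhibition:
- compound 1, `CCCn1c(=O)[nH]c2nc(-c3ccc(S(=O)(=O)N4CCN(c5ccc(F)cc5)CC4)cc3)[nH]c2c1=O`: 0.644 nM
- compound 2, `CCCn1c(=O)[nH]c2nc(-c3ccc(S(=O)(=O)N4CCN(c5cccc(Cl)c5)CC4)cc3)[nH]c2c1=O`: 0.342 nM
- compound 3, `CCCn1c(=O)[nH]c2nc(-c3ccc(S(=O)(=O)N4CCN(c5cccc(Br)c5)CC4)cc3)[nH]c2c1=O`: 0.234 nM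

Compound 3 has the lowest number of the three. The step of a 1.5-fold lower number from compound 2 to compound 3 (0.16 log units; within the scatter) means that these two cannot be ordered; the step of a 2.8-fold lower number from compound 1 to compound 3 (0.44 log units; beyond the scatter) is a modest but real difference.

Compound 4, `CCCn1c(=O)[nH]c2nc(-c3ccc(S(=O)(=O)N4CCN(c5ccc(C)cc5)CC4)cc3)[nH]c2c1=O`, differs from compound 3 by 4-methylphenyl in place of 3-bromophenyl on an amine nitrogen in a ring. All three measured steps concern this same aryl group on the ring nitrogen: a 1.9-fold lower number from compound 1 to compound 2 (0.27 log units; within the scatter), a 2.8-fold lower number from compound 1 to compound 3 (0.44 log units; beyond the scatter) and a 1.5-fold lower number from compound 2 to compound 3 (0.16 log units; within the scatter). Among the compounds with values here, every replacement here moved the number by at most a modest amount, and the only step beyond the scatter ran from the 4-fluorophenyl of compound 1 to the 3-bromophenyl of compound 3. Within the data shown here, a methyl group in the 4-position has no direct precedent; the nearest comparison is compound 1, which also carries its group in the 4-position and gives 0.644 nM.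

For compound 4 the expected step is therefore a 2.1-fold higher number from compound 3 to compound 4 (0.33 log units; beyond the scatter), a small rise that may not exceed the scatter. The estimate for compound 4 in this assay is 0.5 nM, with a range from 0.2 nM to 1.4 nM.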

Compound 4, inhibition constant: 0.706 nM
Estimate against measurement, compound 4: 1.4-fold (0.15 log units) below, and the stated range covers the measured number.
By their numbers in this assay, from the lowest: compounds 3, 2, 1 and 4 (each within the scatter of the next, the first and the last beyond it).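

In this assay, the aryl group on the ring nitrogen now separates in a new pair: 4-methylphenyl in place of 3-chlorophenyl gives a step beyond the scatter (a 2.1-fold higher number from compound 2 to compound 4 (0.31 log units; beyond the scatter)), whereas 3-chlorophenyl and 4-fluorophenyl could not be separated. The step from 3-bromophenyl is similar in kind (a 3.0-fold higher number from compound 3 to compound 4 (0.48 log units; beyond the scatter)), while methyl in place of fluoro leaves the two 4-substituted phenyl groups unordered (a 1.1-fold higher number from compound 1 to compound 4 (0.04 log units; within the scatter)), so the 3-halophenyl groups tend to give the lower numbers, with the pair of compound 1 and compound 2 going against this as a separable step. No measured evidence here accounts for these differences.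

Still open, as far as these compounds go, is whether the ring position or the substituent itself sets the gap. A 3-methylphenyl and a 4-bromophenyl group would separate these two readings, and an unsubstituted phenyl would give a common reference.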